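The source may hold more compounds than are shown below. What is called first, only, known or untested is meant among the compounds shown, and "the series" means these compounds.

Working notes on the series. In a functional assay on MCF7 cells (Homo sapiens) for antiproliferative activity, read by MTT assay (a lower number here means a stronger inhibitor, a higher number a weaker inhibitor), compound 3 `NS(=O)(=O)c1ccc(N/N=C(/CS(=O)(=O)c2ccccc2)c2ccccc2)cc1` gives 3970 nM. Compound 1 `C/C(=N/NC(=O)c1ccc(S(N)(=O)=O)cc1)c1ccc(Br)cc1` gives 2290 nM, which lies within the scatter of compound 3. Compound 2 `C/C(=N/NC(=O)c1ccc(S(N)(=O)=O)cc1)c1ccc(F)cc1` gives 31900 nM, a higher number than compound 3 and beyond the scatter, so compound 3 sits second highest of the three.

Compound 4 `NS(=O)(=O)c1ccc(N/N=C(/CS(=O)(=O)c2ccccc2)c2ccc(Br)cc2)cc1` carries one change from compound 3: bromo in place of hydrogen on an aromatic carbon, para to a large group (bromo in place of hydrogen on an aromatic carbon).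

Within the data shown here, only one measured step bears on this: a 14-fold higher number from compound 1 to compound 2 (1.14 log units; beyond the scatter), a large step, with bromo giving the lower number. Among the measured compounds shown here, it compares two halogens on a different core, and no pair of hydrogen against bromo has been measured, so it gives only a weak lead on direction and little on size. A small move towards a lower number is therefore expected, possibly within the scatter.

The expected change is an estimated 1.8-fold lower number from compound 3 to compound 4 (0.26 log units; within the scatter).

For compound 4 the estimated value is 2200 nM, with an expected range of 700 nM to 6000 nM.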

Compound 4, half-maximal inhibitory concentration: 17300 nM
For compound 4 the middle estimate is 7.9-fold (0.90 log units) below the measured one; measured number above the stated range.
By their numbers in this assay, from the lowest: compounds 1 and 3 (each within the scatter of the next); then compounds 4 and 2 (each within the scatter of the next).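

Among these compounds, compound 3 and compound 4 form the first pair here that isolates hydrogen against bromo on an aromatic carbon, para to a large group. In this assay, phenyl to 4-bromophenyl gives a 4.4-fold higher number from compound 3 to compound 4 (0.64 log units; beyond the scatter), so on this core the added bromo goes with a weaker result, and the halogen step on the other core, a 14-fold higher number from compound 1 to compound 2 (1.14 log units; beyond the scatter), is no guide to this change. No available evidence bears on what lies behind this step.

Still open, going by these compounds, is whether the rise belongs to bromo itself or would also appear with fluoro, methoxy or an amine at this position. Also open, on these data alone, is whether hydrogen to bromo moves the number the same way on the core of compound 1.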